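The compounds below may be only part of what the source reports. "The series", "measured", "known", "first", "only" and "open" are said of these compounds alone.

Measured compounds:
compound 1 `CC(C)OC(=O)N1CCC(Oc2ncnc3c2CCN3c2ccc(-c3nccs3)cc2F)CC1` — 79.4 nM
compound 2 `CCOC(=O)N1CCC(Oc2ncnc3c2CCN3c2ccc(S(C)(=O)=O)cc2F)CC1` — 251 nM
compound 3 `CC(C)OC(=O)N1CCC(Oc2ncnc3c2CCN3c2ccc(S(C)(=O)=O)cn2)CC1` — 126 nM

Three compounds on a shared core have numbers in a functional assay on CHO-K1 cells for agonist activity at Glucose-dependent insulinotropic receptor (Homo sapiens), read by a luciferase reporter, with a stated time of 5 h; a higher number here means that more compound is needed for the effect, a lower number that less compound is needed. Compound 1 gives 79.4 nM, compound 2 gives 251 nM and compound 3 gives 126 nM. Compound 3 holds the second highest of the three numbers; its nearest neighbour is compound 1, within the scatter, and its furthest is compound 2, also within the scatter. None of the three is separated from another beyond the scatter.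

Compound 4 `CC(C)OC(=O)N1CCC(Oc2ncnc3c2CCN3c2ccc([S@+](C)[O-])c(F)c2)CC1` is not yet measured. It differs from compound 3 in one place: a group of 10 heavy atoms (7 carbon, 1 oxygen, 1 fluorine, 1 sulfur; one six-membered aromatic ring of carbon only) in place of a group of 10 heavy atoms (6 carbon, 1 nitrogen, 2 oxygen, 1 sulfur; one six-membered aromatic ring with 1 hetero atom), on a nitrogen on an aromatic ring in a ring. Among the measured compounds shown here, no pair of measured compounds differing in a single place is available, so no measured step can be borrowed for this change. The group on that nitrogen varies across the measured set while the values stay within the scatter, and compound 3 at 126 nM and compound 1 at 79.4 nM are within the scatter of each other; the step is therefore expected to be small, a 1.3-fold higher number from compound 3 to compound 4 (0.10 log units; within the scatter), with no direction beyond the scatter. Compound 4 is estimated at 160 nM, in the range 50 nM to 500 nM.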

Compound 4, half-maximal effective concentration: 50.1 nM
Compound 4: middle estimate off by 3.2-fold (0.50 log units), on the high side; measured number inside the range.
By their numbers in this assay, from the lowest: compounds 4, 1, 3 and 2 (each within the scatter of the next, the first and the last beyond it).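

In this assay, among the compounds shown here, the group on a nitrogen on an aromatic ring in a ring gives the first single-place change with a step beyond the scatter: a 2.5-fold lower number from compound 3 to compound 4 (0.40 log units; beyond the scatter), modest in size. The 5-(methylsulfonyl)pyridin-2-yl group gives way to a group with a six-membered aromatic ring of carbon only, bearing fluorine and sulfur with one oxygen and a defined stereocentre, so several features change together and the step cannot be assigned to any one of them. No measurement at hand accounts for this step.

Still open, going by these compounds, is which of these features carries the step, and whether the opposite configuration at the stereocentre gives the same number. A nitrile or a carboxylic acid in place of the sulfur-bearing group would test how far this position tolerates other groups.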